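Swapping chloro for methoxy on a sulfonamide-bearing pyridine

A few compounds are considered here, and "the series" means these few. Any claim that something is new, unique, unknown or untested is made for them only; others in the source may bear on it.

Of the compounds shown here, two of a shared core have been measured in a functional assay on HCT-116 cells (Homo sapiens) for cytotoxicity, read by MTT assay, with a stated time of 72 h; a higher number here means a weaker inhibitor, a lower number a stronger inhibitor. Compound 1 `COc1ncc(-c2ccc3nccc(-c4ccc(Cn5cncn5)cc4)c3c2)cc1NS(=O)(=O)c1ccc(F)cc1F` gives 8.7 nM. Compound 2 `O=S(=O)(Nc1cc(-c2ccc3nccc(-c4ccc(Cn5cncn5)cc4)c3c2)cnc1Cl)c1ccc(F)cc1` gives 33 nM, the higher of the two numbers, and the gap between compound 2 and compound 1 lies beyond the usual scatter; the two differ at more than one place, so no single change can be read from that gap.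

Compound 3 `COc1ncc(-c2ccc3nccc(-c4ccc(Cn5cncn5)cc4)c3c2)cc1NS(=O)(=O)c1ccc(F)cc1` differs from compound 2 in one place: methoxy in place of chloro on an aromatic carbon. Compound 3 thereby carries the same methoxy as compound 1 while keeping the sulfonyl aryl of compound 2. Because compound 1 gives 8.7 nM with that methoxy, a move to a lower number is expected for compound 3, of moderate size, and the expected step is a 2.2-fold lower number from compound 2 to compound 3 (0.34 log units; beyond the scatter). In this assay compound 3 is estimated at 15 nM, within a range from 5 nM to 45 nM.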

Compound 3, half-maximal inhibitory concentration: 26 nM
Beside the measured number, compound 3's estimate is 1.7-fold (0.24 log units) below it; low and high end bracket the measured number.
By their numbers in this assay, from the lowest: compound 1; then compounds 3 and 2 (each within the scatter of the next).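

In this assay, methoxy in place of chloro on the aromatic carbon next to the ring nitrogen gives a 1.3-fold lower number from compound 2 to compound 3 (0.10 log units; within the scatter) and so does not separate these two groups at this position, although methoxy brings an oxygen and one more heavy atom. Among these compounds, the one step that lies beyond the scatter sits on the sulfonyl aryl instead, where hydrogen in place of fluoro on an aromatic carbon gives a 3.0-fold higher number from compound 1 to compound 3 (0.48 log units; beyond the scatter) and shows that this ring responds to a single atom in a way the pyridine position has not. No measurement is available that would explain either step.

On these data alone, it remains open whether this position would respond to a different kind of group, such as an amine, a nitrile or a longer alkoxy chain. As far as these compounds go, it is also open whether the fluoro step on the sulfonyl aryl would hold with chloro on the pyridine.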